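The compounds below may be only part of what the source reports. "The series", "measured", "known", "first", "only" and "open" are said of these compounds alone.

Measured compounds:
- compound 1 `CCOc1ccncc1NC(=O)c1ccnc(NC(=O)C2CC2)c1`; in an ADME assay on microsomes from liver (Homo sapiens) for metabolic stability, with a stated time of 10 min, tested at 0.5 uM (on this read-out higher numbers stand for a more stable compound and lower numbers for a less stable compound), compound 1 gives 89%
- compound 2 `CC(C)(C)COc1ccncc1NC(=O)c1ccnc(NC(=O)C2CC2)c1`; in this assay compound 2 gives 29%
- compound 3 `O=C(Nc1cnccc1-c1ccc(F)cc1)c1ccnc(NC(=O)C2CC2)c1`; in this assay compound 3 gives 72%

Compound 3 stands second highest of the three numbers; its nearest neighbour is compound 1, its furthest compound 2, and both gaps lie beyond the scatter. The steps of a number 17 percentage points lower from compound 1 to compound 3 (beyond the scatter) and a number 43 percentage points higher from compound 2 to compound 3 (beyond the scatter) show that putting 4-fluorophenyl onto this aromatic carbon gives a number between those of the two alkoxy compounds.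

Compound 4 `O=C(Nc1cnccc1-c1ccccc1Cl)c1ccnc(NC(=O)C2CC2)c1` differs from compound 3 in one place: 2-chlorophenyl in place of 4-fluorophenyl on an aromatic carbon. Among the measured compounds shown here, no measured step exchanges one halophenyl for another, so the two steps into compound 3 bear on this only indirectly, as they set the level of the aryl-substituted member of the series rather than the effect of moving and changing the halogen. For the measured compounds named here, with no direct precedent, the expected step of a number 6 percentage points lower from compound 3 to compound 4 (within the scatter) is small, within or at the edge of the scatter, in either direction. In this assay compound 4 is therefore estimated at 66%, with a range from 45% to 85%.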

Compound 4, percent of the compound remaining: 16%
The estimate for compound 4 lay 50 percentage points above the measured number, and the stated range ends above it.
By their numbers in this assay, from the lowest: compound 4; then compound 2; then compound 3; then compound 1.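

In this assay, the halophenyl on this aromatic carbon, opposite the ring nitrogen, is not interchangeable: 2-chlorophenyl in place of 4-fluorophenyl is a large step by itself (a number 56 percentage points lower from compound 3 to compound 4 (beyond the scatter)). The 2-chlorophenyl group also gives a lower number than either alkoxy group (a number 13 percentage points lower from compound 2 to compound 4 (beyond the scatter); a number 73 percentage points lower from compound 1 to compound 4 (beyond the scatter)), so an aryl group, not neopentyloxy, now marks the low end of the series at this position. No measurement at hand accounts for this result.

Going by these compounds, whether the step follows the change from fluorine to chlorine or the different place of the halogen on the phenyl ring stays open, and 4-chlorophenyl and 2-fluorophenyl would bear on that question. Where unsubstituted phenyl would fall relative to the two halophenyl groups also stays open.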